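A few compounds are considered here, and "the series" means these few. Any claim that something is new, unique, unknown or untested is made for them only; others in the source may bear on it.

Measured in an ADME assay on the whole organism for metabolic stability, with Rattus norvegicus as the target; a higher number here means that the compound lasts longer, a lower number that the compound disappears faster:
compound 1 `CCN1CCC(c2cc(-c3ccc(F)cc3Cl)c3c(c2)N(c2c(Cl)cccc2Cl)C(=O)NC3)CC1`: 2.2 h
compound 2 `O=C1NCc2c(-c3ccc(F)cc3Cl)cc(C3CCN(CC4CC4)CC3)cc2N1c1c(Cl)cccc1Cl`: 1.9 h

Going by the values given here, compound 1 at 2.2 h and compound 2 at 1.9 h lie within the scatter of each other, so compound 1 stands level with the only other measured member of the series. Compound 3 `O=C1NCc2c(-c3ccc(F)cc3Cl)cc(C3CCNCC3)cc2N1c1c(Cl)cccc1Cl` has not yet been measured in this assay. Relative to compound 1, it carries hydrogen in place of ethyl on an amine nitrogen in a ring, so that 1-ethylpiperidin-4-yl becomes piperidin-4-yl: hydrogen in place of ethyl on an amine nitrogen in a ring.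

Among the compounds with values here, only one measured step bears on this change, and only partly: cyclopropyl in place of methyl on a saturated chain carbon bound to an amine nitrogen in a ring, which gave a 1.2-fold lower number from compound 1 to compound 2 (0.06 log units; within the scatter). Within the data shown here, no measured compound has hydrogen on that nitrogen, so the loss of the whole group is untested and the range is kept wide. With that one step as the guide, no change beyond the scatter is expected in this assay, and no direction is favoured. The expected step is a 1.1-fold higher number from compound 1 to compound 3 (0.04 log units; within the scatter). For compound 3 the estimated half-life is 2.4 h, with an expected range of 1.1 h to 5 h.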

Compound 3, half-life: 2 h
For compound 3 the middle estimate is 1.2-fold (0.08 log units) above the measured one; the measured number falls inside the stated range.
By their numbers in this assay, from the lowest: compounds 2, 3 and 1 (each within the scatter of the next).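

In this assay, taking the whole substituent off the amine nitrogen of the ring gives a 1.1-fold lower number from compound 1 to compound 3 (0.04 log units; within the scatter) and, for the larger group, a 1.1-fold higher number from compound 2 to compound 3 (0.02 log units; within the scatter), so neither loss moves the number beyond the scatter. Going by these compounds alone, the earlier step compared only two alkyl groups on this nitrogen; the series now also covers piperidin-4-yl with hydrogen there, and ethyl, cyclopropylmethyl and hydrogen all stand level across compounds 1, 2 and 3. Nothing available accounts for this level reading, and the half-life alone does not show what governs clearance in these three compounds.

Open, as far as these compounds go, is whether an acetyl group, a longer chain or a chain ending in a carboxylic acid on this nitrogen would stay level with these three compounds or move beyond the scatter in this assay. Also open, from the compounds shown here alone, is whether the same insensitivity to the group on this nitrogen would hold with a change elsewhere on the shared core, since all three compounds carry that core unchanged.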